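The source may report more compounds than this note shows. Statements on the series, on what has been measured and on what is new or still open speak of the compounds shown alone.

Measured so far in a functional assay on A549 cells (Homo sapiens) for antiproliferative activity, read by MTT assay, with a stated time of 72 h; a higher number here means a weaker inhibitor, a lower number a stronger inhibitor:
Compound 1 `COc1cc2ncnc(Nc3cccc(Cl)c3)c2cc1OCCCN1CCNCCNCCNCC1`: 27100 nM
Compound 2 `COc1cccc(Nc2ncnc3cc(OC)c(OCCCN4CCNCCNCCNCC4)cc23)c1`: > 50000 nM (a limit of the assay, not a number)

Compound 2 has no exact value, only a limit of > 50000 nM. Its true position in this assay is therefore open on one side.

The next compound, compound 3 `COc1cc2ncnc(Nc3cccc(I)c3)c2cc1OCCCN1CCNCCNCCNCC1`, differs from compound 2 in one place: iodo in place of methoxy on an aromatic carbon. In other words, 3-methoxyphenyl becomes 3-iodophenyl.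

Among the measured compounds shown here, one measured step bears on this change: an at least 1.8-fold higher number from compound 1 to compound 2 (0.26 log units; that floor lies within the scatter), where methoxy took the place of chloro on an aromatic carbon. That step is small on its floor and gives only a weak guide. Still, compound 3 gives up the methoxy for another halogen, so compound 1, with 27100 nM, is the closest measured reference. A modest move to a lower number in this assay is therefore expected, though the size is uncertain with a limit as the starting point. The expected change is an at least 2.0-fold lower number from compound 2 to compound 3 (0.30 log units; that floor lies within the scatter).

The estimated value for compound 3 is 25000 nM, with an expected range of 10000 nM to 50000 nM.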

Compound 3, half-maximal inhibitory concentration: 14500 nM
The estimate for compound 3 lay 1.7-fold (0.24 log units) above the measured number; the range from low to high includes it.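

In this assay, among the compounds shown here, iodo in place of methoxy gives the first step at this position that lies clearly beyond the scatter: an at least 3.4-fold lower number from compound 2 to compound 3 (0.53 log units; beyond the scatter). From the compounds shown here alone, the true size of that step stays unknown because compound 2 has only a limit of the assay, so the printed figure is a floor: the limit of > 50000 nM in this assay, at which 1 of the 3 values shown sits. Iodo in place of chloro gives a 1.9-fold lower number from compound 1 to compound 3 (0.27 log units; within the scatter), so compound 1 and compound 3 cannot be told apart in this assay, and a change between these two halogens on this aromatic carbon shows no measurable effect.

The compounds shown leave open whether the difference from methoxy belongs to halogens as a class or only to chloro and iodo, since a bromo or fluoro group at this place, or an amine or a carboxylic acid, would be needed to test that. They also leave open how far compound 2 truly lies from the two halogen compounds, and whether the same order of groups would hold with a shorter chain on the core.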